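Removing the para methyl from compound 3

This account rests on a few compounds, and the source may have more. Where it says the series, first, only, none or still open, it means among the compounds named here.

Measured in a functional assay on A549 cells (Homo sapiens) for inhibition, read by MTT assay, with a stated time of 72 h; on this read-out lower numbers stand for stronger inhibition and higher numbers for weaker inhibition
- compound 1 `Cc1ccc(-c2nnc(SCCCN3CCN(c4nc5ccccc5o4)CC3)o2)cc1` gives 106000 nM
- compound 2 `Oc1ccc(-c2nnc(SCCCN3CCN(c4nc5ccccc5o4)CC3)o2)cc1` gives 181000 nM
- compound 3 `Cc1ccc(-c2nnc(SCCCN3CCN(c4nc5ccccc5s4)CC3)o2)cc1` gives 53900 nM

Compound 3 at 53900 nM has the lowest number of the three, but only compound 2 at 181000 nM lies apart from it beyond the scatter. The remaining link is a 2.0-fold lower number from compound 1 to compound 3 (0.29 log units; within the scatter), so those two cannot be ordered.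

Compound 4 `c1ccc(-c2nnc(SCCCN3CCN(c4nc5ccccc5s4)CC3)o2)cc1` is unmeasured and differs from compound 3 by hydrogen in place of methyl on an aromatic carbon. Going by the values given here, no measured step removes a methyl without a replacement. The closest evidence is a 1.7-fold higher number from compound 1 to compound 2 (0.23 log units; within the scatter), where hydroxy replaces the same methyl. That change at this aromatic carbon stayed small. The other measured step, a 2.0-fold lower number from compound 1 to compound 3 (0.29 log units; within the scatter), lies elsewhere in the molecule and bears on the change only as a measure of how little the series has moved so far.

No step beyond the scatter is therefore expected in this assay, and no direction is favoured. The expected step is a 1.1-fold higher number from compound 3 to compound 4 (0.05 log units; within the scatter). For compound 4 the estimated value is 60000 nM, with an expected range of 30000 nM to 120000 nM.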

Compound 4, half-maximal inhibitory concentration: 257000 nM
For compound 4 the middle estimate is 4.3-fold (0.63 log units) below the measured one, and the stated range ends below it.
By their numbers in this assay, from the lowest: compounds 3, 1, 2 and 4 (each within the scatter of the next, the first and the last beyond it).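

In this assay, the change from 4-methylphenyl to phenyl gives a 4.8-fold higher number from compound 3 to compound 4 (0.68 log units; beyond the scatter), so this aromatic carbon, para to a large group, can respond to a single-atom change even though the methyl is only one heavy atom. Going by these compounds alone, the only earlier step at this carbon, a 1.7-fold higher number from compound 1 to compound 2 (0.23 log units; within the scatter), swapped the same methyl for hydroxy with a 1,3-benzoxazol-2-yl on the ring amine and gave no readable change, whereas the present step has 1,3-benzothiazol-2-yl there, so the two steps differ in both the entering group and the background. Nothing available bears on why loss of the methyl moves the number.

As far as these compounds go, it remains open whether the step belongs to the methyl position alone or depends on the 1,3-benzothiazol-2-yl, which the same change on a 1,3-benzoxazol-2-yl partner would test. From the compounds shown here alone, it is also open whether an ethyl, a methoxy or an amine at this carbon would keep the number near that of compound 3 at 53900 nM or shift it in either direction.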